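Indazole series, acrylic acid tamoxifen-like scaffolds: compound 4

The compounds below may be only part of what the source reports. "The series", "measured", "known", "first", "only" and "open" are said of these compounds alone.

Measured so far in a functional assay on MCF7 cells (Homo sapiens) for cytotoxicity, read by CellTiter-Glo, with a stated time of 5 days; on this read-out lower numbers stand for stronger inhibition and higher numbers for weaker inhibition:
compound 1 `O=C(O)/C=C/c1ccc(/C(=C(\c2ccccc2)C2CCC2)c2ccc3[nH]ncc3c2)cc1`: 1.4 nM
compound 2 `O=C(O)/C=C/c1ccc(/C(=C(\c2ccccc2)C2CCCCC2)c2ccc3[nH]ncc3c2)cc1`: 64 nM
compound 3 `CC/C(=C(/c1ccc(/C=C/C(=O)O)cc1)c1cc2cn[nH]c2cn1)c1ccccc1`: 442 nM

Compound 3 stands at the highest number of the three. Its nearest neighbour is compound 2, and compound 1 lies furthest away; both gaps are beyond the scatter. Going by the values given here, the one measured step, a 46-fold higher number from compound 1 to compound 2 (1.66 log units; beyond the scatter), concerns the ring on the double-bonded chain carbon and does not touch the aromatic bicyclic group.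

Compound 4 `CC/C(=C(/c1ccc(/C=C/C(=O)O)cc1)c1cc2cn[nH]c2cc1F)c1ccccc1` differs from compound 3 in exactly that bicyclic group: a group of 10 heavy atoms (7 carbon, 2 nitrogen, 1 fluorine; one five-membered aromatic ring with 2 hetero atoms, one six-membered aromatic ring of carbon only) in place of a group of 9 heavy atoms (6 carbon, 3 nitrogen; one five-membered aromatic ring with 2 hetero atoms, one six-membered aromatic ring with 1 hetero atom), on a double-bonded chain carbon bound to an aromatic carbon and a double-bonded chain carbon. Among the compounds with values here, no measured pair isolates this change. The group that enters, apart from its fluorine, is the one carried at the same place by compound 1 and compound 2, but those two also differ from compound 3 in the ethyl, so their numbers give only a loose hint that the bicyclic group of compounds 1 and 2 goes with lower numbers in this assay.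

On that hint, a lower number is expected for compound 4 than for compound 3, with wide uncertainty: the step of a 3.7-fold lower number from compound 3 to compound 4 (0.57 log units; beyond the scatter) is estimated. Compound 4 is expected to give about 120 nM, within a range from 25 nM to 600 nM.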

Compound 4, half-maximal inhibitory concentration: 47 nM
Estimate against measurement, compound 4: 2.6-fold (0.41 log units) above; low and high end bracket the measured number.
By their numbers in this assay, from the lowest: compound 1; then compounds 4 and 2 (each within the scatter of the next); then compound 3.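

Going by these compounds alone, with the ethyl held fixed, this is the first pair in which only the bicyclic group changes, on a double-bonded chain carbon bound to an aromatic carbon and a double-bonded chain carbon. In this assay, placing 6-fluoro-1H-indazol-5-yl there instead of the group whose six-membered aromatic ring has 1 hetero atom gives a 9.4-fold lower number from compound 3 to compound 4 (0.97 log units; beyond the scatter) and is a modest step. The earlier step touched only the ring on the other double-bonded chain carbon, so this pair adds direct evidence that the number also responds to the group at this place, and no measurement available here assigns an origin to the step.

The step joins two changes, the loss of the hetero atom from the six-membered ring and the entry of the fluorine, and the compounds shown do not separate their contributions. Still open, going by these compounds, is how the ethyl scaffold reads with 1H-indazol-5-yl carrying no fluorine, and with a chlorine or a methyl in place of the fluorine.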